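Dihydrofolate reductase series: halogen exchange on the diamino core

The compounds below may be only part of what the source reports. "The series", "measured", "known", "first", "only" and "open" are said of these compounds alone.

Measured compounds:
- compound 1 `CCc1cc(Cc2cc(Cc3cc(CC)c(O)c(CC)c3)c(N)nc2N)cc(CC)c1O`: about 1000000 nM
- compound 2 `COc1cc(CC2=CC(Cc3cc(OC)c(O)c(OC)c3)C(=O)N=C2N)cc(OC)c1O`: 14000000 nM
- compound 3 `COc1cc(Cc2cnc(N)c(F)c2N)cc(OC)c1O`: about 35000000 nM

In an assay for inhibition of Dihydrofolate reductase (Rattus norvegicus) (on this read-out higher numbers stand for weaker inhibition and lower numbers for stronger inhibition), compound 3 gives the highest of the three numbers. Compound 2 sits nearest, with a lower number than compound 3 by a gap beyond the scatter, and compound 1 lies furthest, lower still. Compound 4 `COc1cc(Cc2cnc(N)c(Br)c2N)cc(OC)c1O` is not yet measured in this assay. It differs from compound 3 by bromo in place of fluoro on an aromatic carbon. Going by the values given here, no step between measured compounds addresses this exchange, so the change is judged only from compound 3 itself. The step from compound 3 to compound 4 is expected to be small, a 1.4-fold lower number from compound 3 to compound 4 (0.15 log units; within the scatter), not beyond the scatter. Compound 4 is estimated at 25000000 nM, within 6000000 nM to 100000000 nM.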

Compound 4, half-maximal inhibitory concentration: about 42000000 nM
Compound 4: middle estimate off by 1.7-fold (0.23 log units), on the low side, and the stated range covers the measured number.
By their numbers in this assay, from the lowest: compound 1; then compound 2; then compounds 3 and 4 (each within the scatter of the next).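

In this assay, bromo in place of fluoro on the aromatic carbon ortho to two amino groups gives a 1.2-fold higher number from compound 3 to compound 4 (0.08 log units; within the scatter). This step is within the scatter, so the read-out does not separate these two halogens at this position. No available measurement bears on the reason for this result.

From the compounds shown here alone, whether an amine or a carboxylic acid on this carbon would shift the number remains open. So does whether the same halogen exchange would stay within the scatter on the core of compound 1.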